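This account rests on a few compounds, and the source may have more. Where it says the series, first, only, none or still open, it means among the compounds named here.

Series of ureas on a shared core. Compound 1 `O=C(Nc1c(F)cc(F)cc1F)N(Cc1ccc(-c2cccs2)cc1)C1CCCCCC1` stops at the floor of a functional assay on a cell-free system (plasma) with sterol O-acyltransferase, Soat (Rattus norvegicus) as the target; a lower number here means that less compound is needed, a higher number that more compound is needed for the effect: in this assay compound 1 gives > 1 mg/kg, a limit rather than a number. Compound 2 `O=C(Nc1c(F)cc(F)cc1F)N(Cc1ccc(-c2ccsc2)cc1)C1CCCCCC1` likewise gives only a limit in this assay, > 1 mg/kg. The step that the two limits leave unreadable from compound 1 to compound 2 is therefore unreadable. Compound 3 `Cc1cc(C)c(NC(=O)N(Cc2ccc(-c3ccsc3)cc2)C2CCCCCC2)c(C)c1` gives 0.51 mg/kg in this assay, reached by an at least 1.9-fold lower number from compound 2 to compound 3 (0.29 log units; that floor lies within the scatter). Two of the three values sit at a limit (the limit of > 1 mg/kg in this assay, at which 2 of the 3 values shown sit), so compound 2 stands only at that floor. Compound 4 `O=C(Nc1c(F)cc(F)cc1F)N(Cc1ccc(-n2cccc2)cc1)C1CCCCCC1` differs from compound 2 by 1H-pyrrol-1-yl in place of thiophen-3-yl on an aromatic carbon. Going by the values given here, no measured step covers this exchange; the one prior change at the same position is unreadable. For compound 4 no step beyond the scatter is expected, a step that the limit leaves unreadable from compound 2 to compound 4. Compound 4 is thus estimated at 1.5 mg/kg in this assay, between 0.5 mg/kg and 5 mg/kg, with a fair chance of a limit again.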

Compound 4, dose for half-maximal effect: > 1 mg/kg
Compound 4 ended at the assay's limit (the forecaster's own chance of this, stated with the estimate: 55%); the middle value is on the limit's open side.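

In this assay compound 4 gives the limit > 1 mg/kg and, like compound 1 and compound 2, yields no readable new step. On these data alone, whether 1H-pyrrol-1-yl, thiophen-2-yl and thiophen-3-yl differ at all alongside 2,4,6-trifluorophenyl remains open.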